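The source may hold more compounds than are shown below. What is called first, only, known or untested is meant among the compounds shown, and "the series" means these compounds.

Of the compounds shown here, two have been measured in an ADME assay on TZM cells (Homo sapiens) for cytotoxicity, read by MTT assay, with a stated time of 48 h; on this read-out lower numbers stand for higher toxicity in this test and higher numbers for lower toxicity in this test. Compound 1 `O=C1CSC(c2c(F)cccc2Cl)N1C(=O)Nc1ccncc1` gives 105000 nM, and compound 2 `COc1cc(OC)nc(N2C(=O)CSC2c2c(Cl)cccc2Cl)n1` gives 85400 nM. The gap between these two numbers lies within the usual scatter of repeated measurements, so compound 1 and compound 2 stand together rather than apart, and nothing separates them on this read-out.

Compound 3 `O=C1CSC(c2c(Cl)cccc2Cl)N1C(=O)Nc1ccncc1` is the next compound to be tested in this assay. It differs from compound 1 in one place: chloro in place of fluoro on an aromatic carbon. For the measured compounds named here, no measured pair shows this change on its own, so the size of the step is not known from the data. Given that compound 2, which carries two chloro groups on the same ring, gives 85400 nM, the expected step from compound 1 to compound 3 is small, a 1.2-fold lower number from compound 1 to compound 3 (0.07 log units; within the scatter), and not beyond the scatter. Compound 3 is therefore estimated at 90000 nM, with a likely range from 40000 nM to 200000 nM.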

Compound 3, half-maximal cytotoxic concentration: 170000 nM
Compound 3: middle estimate off by 1.9-fold (0.28 log units), on the low side; measured number inside the range.
By their numbers in this assay, from the lowest: compounds 2, 1 and 3 (each within the scatter of the next).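

At this position, on an aromatic carbon ortho to a large group and meta to a chloro group, chloro in place of fluoro gives a 1.6-fold higher number from compound 1 to compound 3 (0.21 log units; within the scatter) in this assay. This is a direct reading of the change, which compound 1 and compound 2 alone could not give, and it lies within the scatter, so compound 1 and compound 3 stand together on this read-out. No measurement shown here speaks to why the step has this size.

Going by these compounds, whether a different group at this position, such as an amine or a methyl group, would give a step beyond the scatter remains open. For the compounds shown here, it also remains open whether chloro in place of fluoro reads the same way on other compounds, as this single pair is the only reading of the change.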